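Notes on the chain substituent series, step to compound 4

A few compounds are considered here, and "the series" means these few. Any claim that something is new, unique, unknown or untested is made for them only; others in the source may bear on it.

Measured so far:
compound 1 `Cc1nc2c(OCc3ccccc3)cccn2c1C#N`, 4%
compound 2 `Cc1nc2c(OCc3ccccc3)cccn2c1CCC#N`, 20%
compound 3 `Cc1nc2c(OCc3ccccc3)cccn2c1CC(=O)O`, 24%

For the measured compounds named here, in a functional assay on the whole organism (stomach) for inhibition, with Canis familiaris (Canis lupus familiaris) as the target, at a dose of 5 mg/kg by the intravenous route (a higher number here means a stronger effect of the compound at the dose given, a lower number a weaker effect), compound 3 gives the highest number of the three, but its lead over compound 2 lies within the scatter, as the step of a number 4 percentage points higher from compound 2 to compound 3 (within the scatter) shows; only the step of a number 20 percentage points higher from compound 1 to compound 3 (beyond the scatter) is beyond it. Compound 4 `CC(=O)OCc1c(C)nc2c(OCc3ccccc3)cccn12` differs from compound 3 in one place: acetoxy in place of carboxy on a saturated chain carbon bound to an aromatic carbon.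

Going by the values given here, two measured steps bear on this change. The step of a number 4 percentage points higher from compound 2 to compound 3 (within the scatter) swaps one group on the same saturated chain carbon for another and stays within the scatter. The steps of a number 16 percentage points higher from compound 1 to compound 2 (beyond the scatter) and a number 20 percentage points higher from compound 1 to compound 3 (beyond the scatter) both show that extending the cyano into a longer chain raises the number modestly. Among the compounds with values here, no measured pair exchanges carboxy for acetoxy, so the direction is uncertain; the chain length is kept, and the nearest precedent is flat. A step of a number 4 percentage points lower from compound 3 to compound 4 (within the scatter) is therefore expected, within the scatter. Compound 4 is estimated at 20%, in the range 8% to 35%.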

Compound 4, a percentage reported as inhibition, in the whole organism at one dose (the size of the read-out at that dose, not a potency): 87%
For compound 4 the middle estimate is 67 percentage points below the measured one, outside the stated range (above it).
By their numbers in this assay, from the lowest: compound 1; then compounds 2 and 3 (each within the scatter of the next); then compound 4.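

In this assay the exchange of carboxy for acetoxy on a saturated chain carbon bound to an aromatic carbon gives a number 63 percentage points higher from compound 3 to compound 4 (beyond the scatter), so this position responds strongly to the group carried on the chain, which the flat step a number 4 percentage points higher from compound 2 to compound 3 (within the scatter) did not reveal. For the compounds shown here, the other comparisons agree, with a number 67 percentage points higher from compound 2 to compound 4 (beyond the scatter) and a number 83 percentage points higher from compound 1 to compound 4 (beyond the scatter) both large, whereas the earlier steps were modest at most or within the scatter. Nothing available accounts for the size of this jump.

Going by these compounds, whether the gain belongs to acetoxy itself or would also appear with a hydroxyl, a methoxy or an amide on the same carbon remains open. Also open, on these data alone, are whether a longer chain carrying acetoxy keeps the effect and how compound 4 behaves at other doses.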